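Methoxy for fluoro at the crowded position of compound 3

The source may hold more compounds than are shown below. What is called first, only, known or untested is meant among the compounds shown, and "the series" means these compounds.

Measured so far:
- compound 1 `O=C1NCCc2nc(C#Cc3ccccc3)sc21`: 112 nM
- compound 2 `O=C1NCCc2nc(C#Cc3cccc(F)c3)sc21`: 290 nM
- compound 3 `O=C1NCCc2nc(C#Cc3ccccc3F)sc21`: 1500 nM

In an assay on HEK293 cells for positive allosteric modulation of metabotropic glutamate receptor 5 (Homo sapiens), read by FLIPR, with a stated time of 1 h (a higher number here means that more compound is needed for the effect, a lower number that less compound is needed), compound 3 gives the highest number of the three, with a 13-fold higher number from compound 1 to compound 3 (1.13 log units; beyond the scatter) and, from compound 1, a smaller rise of a 2.6-fold higher number from compound 1 to compound 2 (0.41 log units; beyond the scatter). Compound 4 `COc1ccccc1C#Cc1nc2c(s1)C(=O)NCC2` differs from compound 3 by methoxy in place of fluoro on an aromatic carbon. Within the data shown here, no measured step swaps one group for another at this place; both known steps only introduce fluoro, so they set the scale but not the direction. The step to compound 4 is expected to be a 1.7-fold lower number from compound 3 to compound 4 (0.22 log units; within the scatter) in this assay, with the wider range reflecting that uncertainty. Compound 4 is therefore estimated at 900 nM, between 250 nM and 3500 nM.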

Compound 4, half-maximal effective concentration: > 10000 nM
Compound 4: no number, only a limit; the forecaster's own chance of this, stated with the estimate: 5%; middle value at least 11-fold (1.04 log units) away from the limit.
By their numbers in this assay, from the lowest: compound 1; then compound 2; then compound 3. At a limit, above all of these: compound 4.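

In this assay compound 4 gives only a limit of the assay, > 10000 nM, and not a number. At this aromatic carbon, ortho to a large group, the exchange of fluoro for methoxy gives an at least 6.6-fold higher number from compound 3 to compound 4 (0.82 log units; beyond the scatter). Against hydrogen the same place gives an at least 89-fold higher number from compound 1 to compound 4 (1.95 log units; beyond the scatter), so the rise seen with fluoro is not confined to fluoro and grows further with methoxy.

From the compounds shown here alone, how far compound 4 lies beyond its limit stays open. So does whether a methyl or a hydroxyl group at this place, or methoxy at the fluoro position of compound 2, would behave alike.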